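Removing the Phenyl from Compound 1: an Expected Weaker Inhibitor

The source may hold more compounds than are shown below. What is called first, only, known or untested is meant among the compounds shown, and "the series" means these compounds.

Measured compounds:
compound 1 `O=C(Nc1ccc(C(F)(F)F)cc1)c1cc(Cl)c(-c2ccccc2)cc1O`: 800 nM
compound 2 `O=C(Nc1ccc(Cl)c(Br)c1)c1cc(Cl)ccc1O`: 3070 nM
compound 3 `O=C(Nc1ccc(Cl)cc1)c1ccc2cccnc2c1O`: 380 nM

Of the compounds shown here, three have been tested in a functional assay on NALM-6 cells (Homo sapiens) for cytotoxicity, read by luminescence and CellTiter-Glo, with a stated time of 3 days; a higher number here means a weaker inhibitor, a lower number a stronger inhibitor. Among them compound 1 has the second highest number; the closest is compound 3, which gives 380 nM, a gap beyond the usual scatter, and the furthest is compound 2, which gives 3070 nM, also beyond the scatter.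

Compound 4 `O=C(Nc1ccc(C(F)(F)F)cc1)c1cc(Cl)ccc1O` has not yet been measured. It differs from compound 1 in one place: hydrogen in place of phenyl on an aromatic carbon. Among the compounds with values here, no directly comparable step between measured compounds is available, so the expected size of this change rests on the values themselves. Compound 2, whose structure is nearest to compound 4 in this respect, gives a higher number than compound 1 in this assay, though its other parts differ too.

On this basis compound 4 is expected to be a weaker inhibitor than compound 1, with an estimated step of a 3.1-fold higher number from compound 1 to compound 4 (0.49 log units; beyond the scatter). The estimated value for compound 4 is 2500 nM, in a range from 1000 nM to 7000 nM.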

Compound 4, half-maximal inhibitory concentration: 1210 nM
Compound 4: the middle estimate sits 2.1-fold (0.32 log units) above what was measured, and the stated range covers the measured number.
By their numbers in this assay, from the lowest: compound 3; then compounds 1 and 4 (each within the scatter of the next); then compound 2.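

In this assay, within the data shown here, the first step in one place between measured compounds is a 1.5-fold higher number from compound 1 to compound 4 (0.18 log units; within the scatter), so hydrogen in place of phenyl on this aromatic carbon, ortho to the chloro group, meta to the hydroxy group and para to a large group, gives no difference that can be told from the scatter. Among these compounds, the six carbon atoms of the phenyl ring can therefore leave this position with the two numbers staying within the scatter of each other, something the earlier compounds, none of which differed in only one place, could not show. No measurement shown accounts for this result.

From the compounds shown here alone, whether an amine, a carboxylic acid or a longer alkyl chain on the same carbon would also leave the number within the scatter remains open. So does whether the same step would hold with a group other than trifluoromethyl on the anilide ring.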